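Taking the methoxy group off compound 3

The source may hold more compounds than are shown below. What is called first, only, known or untested is meant among the compounds shown, and "the series" means these compounds.

In a functional assay on LoVo cells (Homo sapiens) for inhibition, read by MTT assay, with a stated time of 24 h (on this read-out higher numbers stand for weaker inhibition and lower numbers for stronger inhibition), compound 3 (`COc1ccccc1-n1cc(CN2C(=O)C[C@@H]3CC[C@@]2(C)C3(C)C)nn1`) gives 70 nM. Compound 1 (`CC1(C)[C@H]2CC[C@]1(C)N(Cc1cn(-c3ccc(C#N)cc3)nn1)C(=O)C2`) gives 90 nM, and the gap, a 1.3-fold lower number from compound 1 to compound 3 (0.11 log units; within the scatter), leaves these two indistinguishable. Compound 2 (`CC1(C)[C@H]2CC[C@]1(C)N(Cc1cn(-c3ccccc3Cl)nn1)C(=O)C2`) gives 190 nM, and a 2.7-fold lower number from compound 2 to compound 3 (0.43 log units; beyond the scatter) places compound 3 clearly on the stronger side of it.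

Compound 4 (`CC1(C)[C@H]2CC[C@]1(C)N(Cc1cn(-c3ccccc3)nn1)C(=O)C2`) has not been measured. It carries hydrogen in place of methoxy on an aromatic carbon, ortho to a large group (hydrogen in place of methoxy on an aromatic carbon), so 2-methoxyphenyl becomes phenyl. Among the measured compounds shown here, no measured compound has this bare phenyl, so no step shows the change directly. The nearest evidence is the methoxy-for-chloro swap between compound 2 and compound 3 already described, together with a 2.1-fold higher number from compound 1 to compound 2 (0.32 log units; beyond the scatter). Both steps are modest, so only a small shift is likely here. The expected step is a 1.6-fold higher number from compound 3 to compound 4 (0.20 log units; within the scatter), leaning towards a higher number in this assay without a clear move beyond the scatter. For compound 4 the estimate is 110 nM, with an expected range of 50 nM to 250 nM.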

Compound 4, half-maximal inhibitory concentration: 50 nM
Beside the measured number, compound 4's estimate is 2.2-fold (0.34 log units) above it; the measured number falls inside the stated range.
By their numbers in this assay, from the lowest: compounds 4, 3 and 1 (each within the scatter of the next); then compound 2.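

Removing the methoxy group changes nothing that can be told apart in this assay: the swap to hydrogen gives a 1.4-fold lower number from compound 3 to compound 4 (0.15 log units; within the scatter), so the 2-methoxyphenyl group is not needed for a number this low. The bare phenyl also cannot be separated from the 4-cyanophenyl group, with a 1.8-fold lower number from compound 1 to compound 4 (0.26 log units; within the scatter), whereas hydrogen in place of chloro gives a 3.8-fold lower number from compound 2 to compound 4 (0.58 log units; beyond the scatter), which leaves compound 2 as the only one of the four clearly on the weaker side. No measured property of these groups is available to account for that gap.

The compounds shown leave open whether an amine or a carboxylic acid at this place, on an aromatic carbon ortho to a large group, would fit with the bare phenyl or stand apart as chloro does. They also leave open what a longer chain, such as ethoxy, would do there.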